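A few compounds are considered here, and "the series" means these few. Any claim that something is new, unique, unknown or untested is made for them only; others in the source may bear on it.

Among the measured compounds shown here, in a functional assay on HeLa cells (Homo sapiens) for cytotoxicity, read by MTT assay, in the presence of a further agent that is not named here (a lower number here means a stronger inhibitor, a higher number a weaker inhibitor), compound 1 `Cc1cn([C@H]2C[C@H](O[Si](C)(C)C(C)(C)C)[C@@H](C3CC(=O)SS3)O2)c(=O)[nH]c1=O` gives 16700 nM and holds the higher of the two numbers so far. Compound 2 `Cc1cn([C@H]2C[C@H](O[Si](C)(C)C(C)(C)C)[C@@H](C3CC(=O)S[S+]3[O-])O2)c(=O)[nH]c1=O` gives 6610 nM and the step (a 2.5-fold lower number from compound 1 to compound 2 (0.40 log units; beyond the scatter)) is modest but beyond the scatter. Compound 3 `Cc1cn([C@H]2C[C@H](O)[C@@H](C3CC(=O)SS3)O2)c(=O)[nH]c1=O` keeps the core of compound 1 and differs by one change (a hydrogen atom in place of a group of 7 heavy atoms (6 carbon, 1 silicon; no ring), on an oxygen on a saturated carbon) on an oxygen on a saturated carbon. The group that leaves has no ring and no common name. For the measured compounds named here, the one measured step (a 2.5-fold lower number from compound 1 to compound 2 (0.40 log units; beyond the scatter)) lies at a different place, on a saturated ring carbon, so it serves only as a gauge of how far a single change has moved the number. Going by the values given here, no measured compound carries the hydrogen on that oxygen, and the direction remains uncertain. The step expected on this estimate is modest and points toward a higher number (a 1.8-fold higher number from compound 1 to compound 3 (0.25 log units; within the scatter)) with a wide margin on either side. For compound 3 the estimated value is 30000 nM with an expected range (8000 nM to 100000 nM).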

Compound 3, half-maximal inhibitory concentration: 54600 nM
Compound 3: middle estimate off by 1.8-fold (0.26 log units), on the low side; the range from low to high includes it.
By their numbers in this assay, from the lowest: compound 2; then compound 1; then compound 3.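

Replacing the group of 7 heavy atoms (6 carbon, 1 silicon; no ring) with a hydrogen atom, on an oxygen on a saturated carbon, gives a 3.3-fold higher number from compound 1 to compound 3 (0.51 log units; beyond the scatter) in this assay and shows that the number responds to a change at this position, not only to the change on the saturated ring carbon. The shift here runs toward a weaker inhibitor, opposite in direction to a 2.5-fold lower number from compound 1 to compound 2 (0.40 log units; beyond the scatter) at that other place, so the series now holds one change that lowers the number and one that raises it, each measured against compound 1. Nothing available explains the rise seen with the hydrogen atom on this oxygen.

From the compounds shown here alone, with only the hydrogen atom and the 7-heavy-atom group seen on this oxygen, it remains open whether a smaller substituent such as methyl or acetyl, or a longer alkyl chain, would give a number between those of compound 3 and compound 1 or fall outside them. Going by these compounds, it also remains open whether the same exchange on the core of compound 2 would move the number by a similar step.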